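Dropping One Methoxy From Compound 1

This account rests on a few compounds, and the source may have more. Where it says the series, first, only, none or still open, it means among the compounds named here.

Within the data shown here, in a functional assay on PC-3 cells (Homo sapiens) for antiproliferative activity, read by MTT assay, with a stated time of 48 h (on this read-out lower numbers stand for stronger inhibition and higher numbers for weaker inhibition), only two numbers exist so far. Compound 1 (`COc1ccc(CN(C(=O)CSc2nc3ccccc3s2)c2cc(OC)c(OC)c(OC)c2)cc1`) gives 8460 nM and so stands as the higher of the two, while compound 2 (`COc1ccc2nc(SCC(=O)N(Cc3ccc(OC)c(O)c3)c3cc(OC)c(OC)c(OC)c3)sc2c1`) gives 4110 nM as the lower number, a gap just beyond the usual scatter. Compound 3 (`COc1cc(N(Cc2ccccc2)C(=O)CSc2nc3ccccc3s2)cc(OC)c1OC`) differs from compound 1 in one place (hydrogen in place of methoxy on an aromatic carbon): hydrogen in place of methoxy on an aromatic carbon, para to a large group, so that 4-methoxybenzyl becomes benzyl. Among the measured compounds shown here, no measured pair shows this change alone, so only a small shift towards weaker inhibition is expected in this assay, one that may well stay within the scatter. The expected step is a 1.2-fold higher number from compound 1 to compound 3 (0.07 log units; within the scatter) on this estimate. Compound 3 is estimated at 10000 nM (expected range 4000 nM to 25000 nM) when it is measured.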

Compound 3, half-maximal inhibitory concentration: 54100 nM
Beside the measured number, compound 3's estimate is 5.4-fold (0.73 log units) below it; the measured number lies above the stated range.
By their numbers in this assay, from the lowest: compound 2; then compound 1; then compound 3.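

In this assay, removing the methoxy from the 4-methoxybenzyl group of compound 1 gives a 6.4-fold higher number from compound 1 to compound 3 (0.81 log units; beyond the scatter), the first single-place step available here. It shows that this position, on the aromatic carbon para to a large group, is not a neutral one: on the core of compound 1, the methoxy there is tied to a clear difference in antiproliferative activity, while the rest of the molecule stays the same. Nothing available explains why this one replacement has an effect of this size.

What remains open is whether the step depends on methoxy in particular, since an ethoxy group, an amine or a carboxylic acid at this place does not appear among the compounds shown. It is also unclear whether the same replacement would give a similar step on the other core substitution seen in compound 2.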